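This account rests on a few compounds, and the source may have more. Where it says the series, first, only, none or still open, it means among the compounds named here.

Two compounds of one series share a fused core and differ only in the group on the saturated ring carbon. Compound 1 `Cc1nn(-c2ncnc3nc[nH]c23)c2c1C(OCc1ccc(C(C)C)cc1)CC(=O)N2` carries an oxygen-linked group there, and in a functional assay on HEK293 cells for agonist activity at G-protein coupled receptor 39 (Homo sapiens), read by scintillation proximity assay and inositol phosphate accumulation, with a stated time of 75 min (on this read-out lower numbers stand for an effect already at smaller amounts and higher numbers for an effect only at larger amounts of compound), compound 1 gives 1690 nM. Compound 2 `Cc1nn(-c2ncnc3nc[nH]c23)c2c1C(NC(=O)Cc1cccs1)CC(=O)N2` carries an amide-linked group at the same place, and in this assay compound 2 gives 244 nM, the lower of the two numbers, so compound 2 stands as the stronger of the pair on what has been measured so far. Compound 3 `Cc1nn(-c2ncnc3nc[nH]c23)c2c1C(OCCn1cccn1)CC(=O)N2` has not yet been tested. It differs from compound 2 in one place: 2-(1H-pyrazol-1-yl)ethoxy in place of (((thiophen-2-yl)methyl)carbonyl)amino on a saturated ring carbon. For the measured compounds named here, no step between two measured compounds matches this change, so the expectation rests on the two values alone. The change returns compound 3 to an oxygen-linked group of the kind seen in compound 1, whose value 1690 nM lies well above that of compound 2. On that basis a 10-fold higher number from compound 2 to compound 3 (1.01 log units; beyond the scatter) is expected, toward the weaker side and beyond the usual scatter. Compound 3 is estimated at 2500 nM, with a range from 600 nM to 10000 nM.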

Compound 3, half-maximal effective concentration: 2270 nM
Beside the measured number, compound 3's estimate is 1.1-fold (0.04 log units) above it, and the stated range covers the measured number.
By their numbers in this assay, from the lowest: compound 2; then compounds 1 and 3 (each within the scatter of the next).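

The step shows that at this saturated ring carbon, in this assay, the move from the amide-linked (((thiophen-2-yl)methyl)carbonyl)amino to 2-(1H-pyrazol-1-yl)ethoxy gives a 9.3-fold higher number from compound 2 to compound 3 (0.97 log units; beyond the scatter). For the compounds shown here, compound 3 also gives the first comparison between two oxygen-linked groups, with (1H-pyrazol-1-yl)methyl in place of 4-isopropylphenyl, and this change gives a 1.3-fold higher number from compound 1 to compound 3 (0.13 log units; within the scatter), so this read-out does not separate the two compounds, and both stand on the weaker side of compound 2. Nothing measured here accounts for either step, and the gap between the amide-linked group and the oxygen-linked groups remains unexplained.

Only one amide-linked group is shown, so it stays open whether the lower number of compound 2 goes with the amide link itself or with the thiophene ring it carries. A plain amine on the same carbon, an amide with a longer chain, or an amide carrying pyrazole in place of thiophene would each bear on that question.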